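Extending the Branched Chain on the Shared Core

A few compounds are considered here, and "the series" means these few. Any claim that something is new, unique, unknown or untested is made for them only; others in the source may bear on it.

The measured compounds:
compound 1, `CC(C)CCn1c(N2CCN(C)CC2)nc2ccccc21`: 1400 nM
compound 2, `CCCCN1CCN(c2nc3ccccc3n2CCOCC)CC1`: 15 nM
compound 3, `CN1CCCN(c2nc3ccccc3n2CCOc2ccccc2)CC1`: 9.1 nM

In a functional assay on ileum for inhibition of histamine H1 receptor (Cavia porcellus) (a higher number here means a weaker inhibitor, a lower number a stronger inhibitor), compound 1 stands at the highest of the three numbers, with 1400 nM. Compound 2 reaches 15 nM and compound 3 reaches 9.1 nM, both well beyond the scatter from compound 1. Both, however, differ from compound 1 in more than one place, so their numbers say nothing about any single change.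

Compound 4, `CCCC(C)Cn1c(N2CCN(C)CC2)nc2ccccc21`, differs from compound 1 in one place: 1-methylbutyl in place of isobutyl on a saturated chain carbon bound to an aromatic nitrogen. For the measured compounds named here, no pair of measured compounds shows this change, so its size is not known from the data here. The chain grows by one carbon and its branch moves, nothing else; the expectation is that the step of a 1.4-fold lower number from compound 1 to compound 4 (0.15 log units; within the scatter) in this assay stays within the usual scatter, with at most a slight drop in the number. Compound 4 is thus expected at 1000 nM, estimated between 350 nM and 3000 nM.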

Compound 4, half-maximal inhibitory concentration: 500 nM
Beside the measured number, compound 4's estimate is 2.0-fold (0.30 log units) above it; the measured number falls inside the stated range.
By their numbers in this assay, from the lowest: compounds 3 and 2 (each within the scatter of the next); then compound 4; then compound 1.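

Putting 1-methylbutyl in place of isobutyl on a saturated chain carbon bound to an aromatic nitrogen gives a 2.8-fold lower number from compound 1 to compound 4 (0.45 log units; beyond the scatter) in this assay. For the compounds shown here, this is the first single change that can be read, and it shows that altering this chain alone, with the rest of the compound the same, moves the number beyond the scatter. Nothing available on hand explains the size of this step.

The compounds shown leave open whether the added carbon or the moved branch accounts for the step, as both change together in this one pair. They also leave open whether a longer unbranched chain such as hexyl, or a ring-bearing group such as cyclohexylmethyl, would carry the number further in the same direction at this position.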